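The compounds below may be only part of what the source reports. "The series", "measured", "known", "first", "only" and "open" are said of these compounds alone.

Three compounds have been measured in a functional assay on CHO cells with metabotropic glutamate receptor 2 (Homo sapiens) as the target, read by GTPgammaS binding; on this read-out lower numbers stand for an effect already at smaller amounts and higher numbers for an effect only at larger amounts of compound:

Compound 1 `CCCc1cnc2c(C#N)c(N3CCN(c4nc(C)cc(C)n4)CC3)ccn12` gives 646 nM.
Compound 2 `N#Cc1c(-c2ccc(N3CCCCC3)cc2)ccn2c(CC(F)(F)F)cnc12` gives 234 nM.
Compound 3 `CCc1cnc2c(C#N)c(N3CCN(c4nc(C)cc(C)n4)CC3)ccn12` gives 2290 nM.

Compound 2 stands lowest of the three numbers in this assay. Its nearest neighbour is compound 1, whose value is a modestly higher number, beyond the scatter; compound 3 lies furthest away, with a value well beyond the scatter from that of compound 2. Among the compounds with values here, the only step measured between compounds that differ in one place runs a 3.5-fold higher number from compound 1 to compound 3 (0.55 log units; beyond the scatter), where hydrogen takes the place of methyl on a saturated chain carbon two bonds along the chain from an aromatic carbon.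

Compound 4 `N#Cc1c(-c2ccc(OCc3ccccc3)cc2)ccn2c(CC(F)(F)F)cnc12` is not yet measured in this assay. It differs from compound 2 in one place: benzyloxy in place of piperidin-1-yl on an aromatic carbon. The change is a replacement of one ring substituent by another on an aromatic carbon, para to a large group. Within the data shown here, none of the measured steps touches this position or either of these groups, so the single measured step gives no direct guide; it only shows that a small change can move the number beyond the scatter. The step of a 2.1-fold higher number from compound 2 to compound 4 (0.33 log units; beyond the scatter) is therefore expected to be uncertain and is given a wide range. Compound 4 is estimated to give 500 nM in this assay, between 100 nM and 2500 nM.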

Compound 4, half-maximal effective concentration: 158 nM
Beside the measured number, compound 4's estimate is 3.2-fold (0.50 log units) above it; the measured number falls inside the stated range.
By their numbers in this assay, from the lowest: compounds 4 and 2 (each within the scatter of the next); then compound 1; then compound 3.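

In this assay the change of benzyloxy in place of piperidin-1-yl on an aromatic carbon, para to a large group, gives a step within the scatter (a 1.5-fold lower number from compound 2 to compound 4 (0.17 log units; within the scatter)), so here a six-membered aromatic ring of carbon only, in a group of 8 heavy atoms, reads the same as a six-membered non-aromatic ring with 1 hetero atom, in a group of 6. Within the data shown here, the only earlier step (a 3.5-fold higher number from compound 1 to compound 3 (0.55 log units; beyond the scatter)) lay on a saturated chain carbon and went beyond the scatter, whereas this result is the first reading at this position and shows that these two quite different groups cannot be told apart by their numbers. No measurement at hand accounts for this close agreement.

On these data alone, with only these two groups at this position, it remains open whether a small group such as methoxy, an open-chain amine such as dimethylamino, or a carboxylic acid would stay as close to compound 2 in this assay. Also open, as far as these compounds go, is whether shortening the chain, which raised the number from compound 1 to compound 3, would have a step of similar size in a compound carrying benzyloxy.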